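The compounds below may be only part of what the source reports. "The series", "measured", "known", "first", "only" and "open" are said of these compounds alone.

Measured so far:
- compound 1, `N#CC1CN1C(=O)Nc1ccc(S(N)(=O)=O)cc1`: > 38000 nM (a limit, not a number)
- compound 2, `N#CC1CN1C(=O)Nc1ccc(C(F)(F)F)cc1`: 4300 nM

Compound 1 reaches only the limit of a functional assay on A549 cells (Homo sapiens) for inhibition (on this read-out higher numbers stand for weaker inhibition and lower numbers for stronger inhibition), giving > 38000 nM, which is a limit rather than a number. Among the compounds with values here, compound 2 gives 4300 nM in this assay and so holds the only number. Within the data shown here, the one measured step, an at least 8.8-fold lower number from compound 1 to compound 2 (0.94 log units; beyond the scatter), is known only as a bound because compound 1 sits at the limit of > 38000 nM in this assay, at which 1 of the 2 values shown sits.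

Compound 3, `N#CC1CN1C(=O)Nc1ccccc1`, is unmeasured. It differs from compound 2 by hydrogen in place of trifluoromethyl on an aromatic carbon. Among the measured compounds shown here, no measured step removes a trifluoromethyl from the shared core; the step from compound 1 to compound 2 exchanges one group for another at the same place and says only that a trifluoromethyl there beats a sulfamoyl. Removing the trifluoromethyl altogether is therefore expected to cost something in this assay, though the size is uncertain, and a step of a 2.1-fold higher number from compound 2 to compound 3 (0.32 log units; beyond the scatter) is estimated. Compound 3 is expected to give about 9000 nM, within 2500 nM to 35000 nM.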

Compound 3, half-maximal inhibitory concentration: 9000 nM
The estimate for compound 3 equals the measured number at the digits printed, and the stated range covers the measured number.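

Compound 3 gives this position a baseline in this assay, so trifluoromethyl can now be read against hydrogen and not only against sulfamoyl: taking trifluoromethyl away gives a 2.1-fold higher number from compound 2 to compound 3 (0.32 log units; beyond the scatter). Sulfamoyl also falls behind hydrogen, as replacing it with hydrogen gives an at least 4.2-fold lower number from compound 1 to compound 3 (0.62 log units; beyond the scatter), so on an aromatic carbon para to a group of 8 heavy atoms, hydrogen sits between the other two groups, and the gain from trifluoromethyl is modest while the loss with sulfamoyl is the larger part of the earlier gap. The size of that loss is known only as a bound because compound 1 stands at a limit: the limit of > 38000 nM in this assay, at which 1 of the 3 values shown sits.

On these data alone, three groups at one place give an order but no rule, and it remains open how a chlorine, a methyl, a methoxy or an amine at the same carbon would read in this assay, or whether a group at another carbon of the aromatic ring would behave alike. The nitrile is common to all the compounds shown, so what it contributes, compared with a carboxylic acid or a plain hydrogen in its place, also stays open.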